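Replacing furan-2-yl with 4-(methylsulfanyl)phenyl on the saturated carbon

A few compounds are considered here, and "the series" means these few. Any claim that something is new, unique, unknown or untested is made for them only; others in the source may bear on it.

Compound 1, `c1ccc(C2CC(c3ccc4c(c3)OCCO4)=NN2c2ccccc2)cc1`, gives 22400 nM in a functional assay on WM 266-4 cells (Homo sapiens) for antiproliferative activity, read by MTT assay, with a stated time of 24 h; a lower number here means a stronger inhibitor of growth, a higher number a weaker inhibitor of growth.
Compound 2, `c1ccc(N2N=C(c3ccc4c(c3)OCCO4)CC2c2cccc3ccccc23)cc1`, gives > 100000 nM in this assay.
Compound 3, `c1ccc(N2N=C(c3ccc4c(c3)OCCO4)CC2c2ccco2)cc1`, gives > 100000 nM in this assay.

Compound 3 stands at a limit of this assay rather than at a measured number. Compound 2 stands at the same limit. Compound 1 is the only one of the three with a number that can be read. The step to the unmeasured compound 4, `CSc1ccc(C2CC(c3ccc4c(c3)OCCO4)=NN2c2ccccc2)cc1`, is 4-(methylsulfanyl)phenyl in place of furan-2-yl on a saturated ring carbon. Going by the values given here, no measured step exchanges these two groups directly. The nearest guide runs the other way: an at least 4.4-fold higher number from compound 1 to compound 3 (0.64 log units; beyond the scatter), and the group entering compound 4 is a phenyl carrying a methylsulfanyl group, so compound 4 resembles compound 1 more closely than compound 3. A move to a lower number in this assay, back toward the value of compound 1, is therefore expected, though the limit of > 100000 nM in this assay, at which 2 of the 3 values shown sit, leaves the true size of that move unreadable. Compound 4 is estimated at 25000 nM, with a range from 8000 nM to 100000 nM. The expected step is then an at least 4.0-fold lower number from compound 3 to compound 4 (0.60 log units; beyond the scatter).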

Compound 4, concentration for 50% growth inhibition: 6870 nM
For compound 4 the middle estimate is 3.6-fold (0.56 log units) above the measured one; measured number outside the range, below it.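

In this assay, a phenyl ring carrying a methylsulfanyl group on this saturated ring carbon gives an at least 14-fold lower number from compound 3 to compound 4 (1.16 log units; beyond the scatter) and an at least 14-fold lower number from compound 2 to compound 4 (1.16 log units; beyond the scatter). Both steps start from a limit and not from a number, so they give only a minimum size: the limit of > 100000 nM in this assay, at which 2 of the 4 values shown sit.

The step that can be read in full shows something new: the phenyl group at this position can be improved, since methylsulfanyl in place of hydrogen on an aromatic carbon gives a 3.3-fold lower number from compound 1 to compound 4 (0.51 log units; beyond the scatter).

With a single substituted phenyl shown, it stays open whether this gain is specific to methylsulfanyl or would also come with a methoxy group, a chlorine atom or a dimethylamino group on the same ring. On these data alone, whether the sulfur atom itself matters also stays open, as a methyl ether or a methylsulfonyl group would be needed to test it.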